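This account rests on a few compounds, and the source may have more. Where it says the series, first, only, none or still open, it means among the compounds named here.

Working notes on the series. The shared core carries a butanoic acid chain on the anilide and varies only at the substituent on an aromatic nitrogen. Compound 1 `CCCCCCCn1ccc2cc(/C(C)=C/C(=O)Nc3ccccc3OCCCC(=O)O)ccc21` gives 120 nM in an assay on Prostate gland for inhibition of steroid 5-alpha-reductase (Rattus norvegicus); on this read-out higher numbers stand for weaker inhibition and lower numbers for stronger inhibition. Compound 2 `CCCC(CC)n1ccc2cc(/C(C)=C/C(=O)Nc3ccccc3OCCCC(=O)O)ccc21` gives 9.3 nM in this assay, and compound 3 `C/C(=C\C(=O)Nc1ccccc1OCCCC(=O)O)c1ccc2c(ccn2Cc2ccccc2C)c1` gives 69 nM in this assay. Compound 2 stands lowest of the three and is the strongest inhibitor, with a 7.4-fold higher number from compound 2 to compound 3 (0.87 log units; beyond the scatter) and, read the other way, a 13-fold lower number from compound 1 to compound 2 (1.11 log units; beyond the scatter).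

Compound 4 `C/C(=C\C(=O)Nc1ccccc1OCCCC(=O)O)c1ccc2c(ccn2Cc2ccc(C(F)(F)F)cc2)c1` has not been measured. It differs from compound 2 by 4-(trifluoromethyl)benzyl in place of 1-ethylbutyl on an aromatic nitrogen. The step that bears most directly on it is a 7.4-fold higher number from compound 2 to compound 3 (0.87 log units; beyond the scatter), where a benzyl group likewise replaced the 1-ethylbutyl group and the number rose by a modest amount beyond the scatter. The step of a 1.7-fold lower number from compound 1 to compound 3 (0.24 log units; within the scatter) shows that two different benzyl-type and chain groups can land within the scatter of one another, so the benzyl replacement here is not expected to be dramatic. A modest rise is therefore expected for compound 4, as a 5.9-fold higher number from compound 2 to compound 4 (0.77 log units; beyond the scatter). The estimate for compound 4 in this assay is 55 nM, within a range of 15 nM to 200 nM.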

Compound 4, half-maximal inhibitory concentration: 300 nM
Compound 4: the middle estimate sits 5.5-fold (0.74 log units) below what was measured; measured number outside the range, above it.
By their numbers in this assay, from the lowest: compound 2; then compounds 3 and 1 (each within the scatter of the next); then compound 4.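

Within the data shown here, the substituent on the aromatic nitrogen proves more sensitive than the earlier compounds showed: the change from 1-ethylbutyl to 4-(trifluoromethyl)benzyl gives a 32-fold higher number from compound 2 to compound 4 (1.51 log units; beyond the scatter), the largest step, and compound 4 is the weakest inhibitor of the four. Benzyl-type groups are also not interchangeable at this position, as the change between the two aryl groups on the saturated chain carbon gives a 4.3-fold higher number from compound 3 to compound 4 (0.64 log units; beyond the scatter), and 4-(trifluoromethyl)phenyl on that carbon also falls behind the hexyl chain, with a 2.5-fold higher number from compound 1 to compound 4 (0.40 log units; beyond the scatter). No measurement bears on the cause of these rises.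

The compounds shown leave open whether the loss in compound 4 follows the trifluoromethyl group itself or its location on the ring, a question that unsubstituted benzyl, 4-methylbenzyl and 2-(trifluoromethyl)benzyl would separate. They also leave open how far branching can be taken on the aromatic nitrogen, for which 1-propylbutyl or cyclohexyl would be the comparison with compound 2.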